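Swapping the aryl group on the anilino nitrogen

The source may report more compounds than this note shows. Statements on the series, on what has been measured and on what is new or still open speak of the compounds shown alone.

Compounds measured so far:
- compound 1, `COc1ccccc1Nc1nc(SCc2cn(Cc3ccccc3Cl)nn2)nc(-c2ccccc2)c1C#N`, 5800 nM
- compound 2, `Cc1cccc(Nc2nc(SCc3cn(Cc4ccccc4Cl)nn3)nc(-c3ccccc3)c2C#N)c1`, 16200 nM

Both compounds were tested in a functional assay on MGC-803 cells (Homo sapiens) for inhibition, read by MTT assay, with a stated time of 72 h; a higher number here means a weaker inhibitor, a lower number a stronger inhibitor. Compound 2 gives the higher of the two numbers, so it is the weaker inhibitor of the pair, and the gap to compound 1 is beyond the usual scatter: a 2.8-fold higher number from compound 1 to compound 2 (0.45 log units; beyond the scatter), a modest step that came with 3-methylphenyl in place of 2-methoxyphenyl on the nitrogen attached to the shared core.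

Compound 3 is `N#Cc1c(Nc2ccccc2F)nc(SCc2cn(Cc3ccccc3Cl)nn2)nc1-c1ccccc1`. It differs from compound 2 in one place: 2-fluorophenyl in place of 3-methylphenyl on a nitrogen on an aromatic ring. Going by the values given here, the only measured step that bears on this change is the one from compound 1 to compound 2, in which a 2-methoxyphenyl was traded for 3-methylphenyl and the number rose. Compound 3 reverses that trade in part, since 2-fluorophenyl, like 2-methoxyphenyl, carries a single substituent and differs from compound 1 only in that substituent. On these data alone, the expected step in this assay is therefore a modest fall in the number, roughly back toward compound 1, though the fluorine is untested here and the step may stay within the scatter; the expected change is a 2.0-fold lower number from compound 2 to compound 3 (0.31 log units; beyond the scatter). Compound 3 is estimated at 8000 nM, with a range from 3000 nM to 20000 nM.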

Compound 3, half-maximal inhibitory concentration: 7580 nM
Compound 3: the middle estimate sits 1.1-fold (0.02 log units) above what was measured, within the range that was stated.
By their numbers in this assay, from the lowest: compounds 1 and 3 (each within the scatter of the next); then compound 2.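

On this nitrogen on an aromatic ring, 2-fluorophenyl in place of 3-methylphenyl gives a 2.1-fold lower number from compound 2 to compound 3 (0.33 log units; beyond the scatter) in this assay, so compound 2 now stands apart from two compounds rather than one, and the step away from 3-methylphenyl has been seen with two different incoming groups. Fluoro in place of methoxy on an aromatic carbon gives a 1.3-fold higher number from compound 1 to compound 3 (0.12 log units; within the scatter) and the two compounds cannot be told apart in this read-out, which shows that the 2-methoxyphenyl of compound 1 is not needed to reach this level, since a 2-fluorophenyl does as well within the scatter. No measured evidence accounts for these numbers.

The three compounds still tie two things together: compound 2 differs from compound 1 and compound 3 both in which group is on the phenyl ring and in where it sits, so the kind of group and its place cannot be separated. On these data alone, whether the step follows the place or the group remains open, and 2-methylphenyl, 3-fluorophenyl, 3-methoxyphenyl or an unsubstituted phenyl on this nitrogen would each bear on that question.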